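Moving the Chlorine Around the Benzyl Ring

The source may report more compounds than this note shows. Statements on the series, on what has been measured and on what is new or still open speak of the compounds shown alone.

Three compounds share one core and differ only in the group on the saturated chain carbon bound to the amine nitrogen in the ring. In an assay for inhibition of Amine oxidase [flavin-containing] A (Homo sapiens), read by fluorescence, using microsomes, with stated times of 20 min and 30 min (on this read-out higher numbers stand for weaker inhibition and lower numbers for stronger inhibition), compound 1 `CCCCN1CCC(Oc2ccc3c(C)c(C)c(=O)oc3c2)CC1` gives 23900 nM, compound 2 `Cc1c(C)c2ccc(OC3CCN(Cc4ccccc4)CC3)cc2oc1=O` gives 3590 nM, and compound 3 `Cc1c(C)c2ccc(OC3CCN(Cc4cccc(Cl)c4)CC3)cc2oc1=O` gives 870 nM, the lowest of the three. The steps of a 6.7-fold lower number from compound 1 to compound 2 (0.82 log units; beyond the scatter) and a 4.1-fold lower number from compound 2 to compound 3 (0.62 log units; beyond the scatter) were both beyond the scatter. Compound 4 `Cc1c(C)c2ccc(OC3CCN(Cc4ccc(Cl)cc4)CC3)cc2oc1=O` differs from compound 3 by 4-chlorophenyl in place of 3-chlorophenyl on a saturated chain carbon bound to an amine nitrogen in a ring. Among the measured compounds shown here, no measured step moves a chloro from one ring position to another, so the earlier steps bear on this change only loosely: they show that adding a chloro helped, not where it must sit. A small step, if any beyond the scatter, is expected, a 1.5-fold higher number from compound 3 to compound 4 (0.17 log units; within the scatter). Compound 4 is therefore estimated at 1300 nM, within a range from 400 nM to 4500 nM.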

Compound 4, half-maximal inhibitory concentration: 1590 nM
Estimate against measurement, compound 4: 1.2-fold (0.09 log units) below; the measured number falls inside the stated range.
By their numbers in this assay, from the lowest: compounds 3 and 4 (each within the scatter of the next); then compound 2; then compound 1.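

Swapping 3-chlorophenyl for 4-chlorophenyl gives a 1.8-fold higher number from compound 3 to compound 4 (0.26 log units; within the scatter) in this assay, so these two placements of the chloro cannot be told apart. The 4-chlorophenyl group still improves on the plain phenyl, with a 2.3-fold lower number from compound 2 to compound 4 (0.35 log units; beyond the scatter) and on the propyl, with a 15-fold lower number from compound 1 to compound 4 (1.18 log units; beyond the scatter) as the larger step. Nothing at hand explains these numbers. Going by these compounds, whether a fluoro, methoxy or trifluoromethyl group in place of the chloro would give similar numbers stays open, as does whether a second chloro on the same ring would add to the first.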